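Replacing the benzyl with 4-chlorophenyl on the piperazine nitrogen

The source may hold more compounds than are shown below. What is called first, only, known or untested is meant among the compounds shown, and "the series" means these compounds.

Of the compounds shown here, three sharing one core have been tested in an ADME assay on CCRF-CEM cells (Homo sapiens) for cytotoxicity, read by MTT assay, with a stated time of 5 days; a higher number here means that more compound is tolerated, a lower number that less compound is tolerated. Compound 2 `COc1cc(Cc2cnc(/N=C3\C(=O)N(CN4CCN(Cc5ccccc5)CC4)c4ccc(Cl)cc43)nc2N)cc(OC)c1OC` gives 94.7 ug/mL, the highest of the three numbers. Compound 1 `COc1cc(Cc2cnc(/N=C3\C(=O)N(CN4CCN(c5c(F)cc6c(=O)c(C(=O)O)cn(C7CC7)c6c5F)CC4C)c4ccc(Cl)cc43)nc2N)cc(OC)c1OC` gives 67 ug/mL in this assay, a value within the scatter of compound 2. Compound 3 `COc1cc(Cc2cnc(/N=C3\C(=O)N(CN(Cc4ccccc4)Cc4ccccc4)c4ccc(Cl)cc43)nc2N)cc(OC)c1OC` gives 37.1 ug/mL in this assay, a number beyond the scatter below compound 2.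

Compound 4 `COc1cc(Cc2cnc(/N=C3\C(=O)N(CN4CCN(c5ccc(Cl)cc5)CC4)c4ccc(Cl)cc43)nc2N)cc(OC)c1OC` has not yet been measured in this assay. It differs from compound 2 in one place: 4-chlorophenyl in place of benzyl on an amine nitrogen in a ring. For the measured compounds named here, no step between measured compounds matches this change, so the direction of the step can only be judged from the spread already seen. Compound 1 also carries an aromatic group directly on that ring nitrogen, and in this assay compound 1 gives 67 ug/mL, which sits within the scatter of compound 2. The step of a 1.5-fold lower number from compound 2 to compound 4 (0.18 log units; within the scatter) is therefore expected to be small, likely downward but probably within the scatter. Compound 4 is estimated to give 62 ug/mL in this assay, with a range from 30 ug/mL to 120 ug/mL.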

Compound 4, half-maximal cytotoxic concentration: 40.1 ug/mL
Compound 4: the middle estimate sits 1.5-fold (0.19 log units) above what was measured; the measured number falls inside the stated range.
By their numbers in this assay, from the lowest: compounds 3, 4, 1 and 2 (each within the scatter of the next, the first and the last beyond it).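

In this assay, for the compounds shown here, the swap gives a 2.4-fold lower number from compound 2 to compound 4 (0.37 log units; beyond the scatter), the first single-place step at this ring nitrogen, so the group held there does affect how much compound the cells tolerate. Benzyl and 4-chlorophenyl have the same heavy-atom count, one six-membered aromatic ring of carbon only, and no hydrogen-bond donors or acceptors, so these shared counts do not settle the outcome at this position. No measurement shown accounts for the step.

The step combines two changes, the loss of the carbon that links the benzyl ring to the nitrogen and the arrival of chlorine, and the compounds shown do not separate them. Phenyl and 4-chlorobenzyl on the same nitrogen would each carry only one of these changes, so they could tell the two apart.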